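The compounds below may be only part of what the source reports. "The series", "measured", "known", "first", "only" and "open" are said of these compounds alone.

Measured compounds in this series:

- compound 1, `COc1cc(OC)c(OC)cc1/C=C/C(=O)c1cc(Cl)ccc1O` — in a functional assay on cells (Erythrocyte, Rattus norvegicus) for inhibition, read by hemolysis, with a stated time of 1 h (a higher number here means a weaker inhibitor, a lower number a stronger inhibitor), compound 1 gives 2.23 ug/mL
- compound 2, `COc1cc(OC)c(-c2cc(=O)c3cc(O)ccc3o2)cc1OC` — in this assay compound 2 gives 2.14 ug/mL

Within the data shown here, compound 1 holds the higher of the two numbers so far, with compound 2 nearest to it; the gap between the two lies within the scatter of repeated measurements, so nothing can be said about an order between them. Among the measured compounds shown here, both values sit in the same narrow band, and no step between measured compounds is available to show how any part of the shared core of compound 1 shifts the read-out.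

The next compound, compound 3, `COc1cc(OC)c(OC)cc1/C=C/C(=O)c1ccc(F)cc1`, differs from compound 1 at one place: 4-fluorophenyl in place of 5-chloro-2-hydroxyphenyl on a carbonyl carbon. Without a measured step of this kind in the series, the size and direction of the change cannot be read off the data. The working expectation is a modest step in this assay toward a weaker inhibitor, estimated as a 2.0-fold higher number from compound 1 to compound 3 (0.30 log units; within the scatter), though a step within the scatter is also plausible. Compound 3 is accordingly estimated at 4.5 ug/mL, with a range from 1.5 ug/mL to 14 ug/mL.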

Compound 3, half-maximal inhibitory concentration: 2.22 ug/mL
Estimate against measurement, compound 3: 2.0-fold (0.31 log units) above, within the range that was stated.
By their numbers in this assay, from the lowest: compounds 2, 3 and 1 (each within the scatter of the next).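

In this assay, among these compounds, the change from 5-chloro-2-hydroxyphenyl to 4-fluorophenyl on the carbonyl carbon gives a 1.0-fold lower number from compound 1 to compound 3 (0.00 log units; within the scatter) and provides the first measured step. The entering group has 0 hydrogen-bond donors and 0 hydrogen-bond acceptors where the leaving group has 1 of each, yet for this pair the read-out stays within the scatter, so the 5-chloro-2-hydroxyphenyl group is not needed to keep the number in this band. No measurement at hand accounts for the size of this step.

The chlorine and the hydroxyl leave together in this single change, so what each contributes alone cannot be read, and effects that cancel each other cannot be told apart from the absence of any effect. As far as these compounds go, it also stays open whether this position tolerates a more different group, such as an amine or a carboxylic acid on the aromatic ring held by the carbonyl carbon, or whether the number would then leave the narrow band seen so far.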